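This account rests on a few compounds, and the source may have more. Where it says the series, first, only, none or still open, it means among the compounds named here.

In a functional assay on the whole organism with Canis familiaris (Canis lupus familiaris) as the target, at a dose of 8 mg/kg by the oral route (on this read-out higher numbers stand for a stronger effect at the one dose given and lower numbers for a weaker effect), compound 1 `CCCCc1nc2c(OCc3ccccc3)cccn2c1N` gives 0%, compound 2 `Cc1nc2c(CCc3ccccc3)cccn2c1N` gives 52%, and compound 3 `CC(=O)Nc1c(C)nc2c(CCc3ccccc3)cccn12` gives 16%. Compound 3 thus stands second highest of the three, nearest to compound 1, whose number is lower, and furthest from compound 2, whose number is higher. Within the data shown here, the one measured step that touches compound 3 runs a number 36 percentage points lower from compound 2 to compound 3 (beyond the scatter), where acetyl replaced hydrogen on a nitrogen on an aromatic ring.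

Compound 4 `CCNc1c(C)nc2c(CCc3ccccc3)cccn12` differs from compound 3 by ethyl in place of acetyl on a nitrogen on an aromatic ring. Among the measured compounds shown here, the only step that bears on this change is the one from compound 2 to compound 3, which was large and downward when the acetyl entered; here the acetyl leaves again, but ethyl rather than hydrogen takes its place, and no measured pair shows ethyl on that nitrogen. Since the loss of the acetyl reverses the change that cost compound 3 its standing relative to compound 2, compound 4 is expected to sit above compound 3, though the ethyl leaves the return to the level of compound 2 uncertain. The step expected is a number 22 percentage points higher from compound 3 to compound 4 (beyond the scatter). Compound 4 is therefore estimated at 38%, within a range from 12% to 62%.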

Compound 4, a percentage reported as inhibition, in the whole organism at one dose (the size of the read-out at that dose, not a potency): 65%
Beside the measured number, compound 4's estimate is 27 percentage points below it, and the stated range ends below it.
By their numbers in this assay, from the lowest: compound 1; then compound 3; then compound 2; then compound 4.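

In this assay, the nitrogen on the aromatic ring turns out to tolerate a substituent. Among these compounds, until now the only change there was the acetyl, which left open whether any group on that nitrogen would weaken the effect. Exchanging acetamido for ethylamino gives a number 49 percentage points higher from compound 3 to compound 4 (beyond the scatter), and measured against the free amine the ethyl gives a number 13 percentage points higher from compound 2 to compound 4 (beyond the scatter), so within these three compounds the loss follows the acetyl and not the mere presence of a group on the nitrogen, and the ethyl even carries the read-out past that of the free amine. Nothing at hand explains why acetyl and ethyl part so widely.

The compounds shown leave open how far this tolerance extends, since only ethyl and acetyl are seen on that nitrogen, and a longer chain such as propyl or butyl, a second ethyl on the same nitrogen, or a carboxylic acid at the end of the chain could go either way. They also leave open whether ethyl would have the same effect on the core of compound 1, and with a single dose as the only read-out, these numbers give the size of the effect at that dose and no potency.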